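This account rests on a few compounds, and the source may have more. Where it says the series, first, only, none or still open, it means among the compounds named here.

Measured so far in an assay on HEK293 cells for positive allosteric modulation of metabotropic glutamate receptor 5 (Homo sapiens), read by FLIPR; on this read-out lower numbers stand for an effect already at smaller amounts and higher numbers for an effect only at larger amounts of compound:
compound 1 `Cc1cccc(-c2noc(C3CN(S(=O)(=O)c4ccc(Cl)cc4)C3)n2)c1`, > 10000 nM
compound 2 `O=C([C@H]1CC2CCC1C2)N1CC(c2nc(-c3ccccc3)no2)C1`, 120 nM
compound 3 `COC1CCN(C(=O)N2CC(c3nc(-c4cccc(Cl)c4)no3)C2)CC1`, > 10000 nM

Compound 3 gives only a limit in this assay, > 10000 nM, and so sits at the limit of > 10000 nM in this assay, at which 2 of the 3 values shown sit. Compound 1 also reports a limit. Compound 2, whose carbonyl carbon carries a carbon-only bicyclic ring, gives 120 nM in this assay.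

Compound 4 `CC1CCCC(C(=O)N2CC(c3nc(-c4cccc(Cl)c4)no3)C2)C1` differs from compound 3 by 3-methylcyclohexyl in place of 4-methoxypiperidin-1-yl on a carbonyl carbon. Within the data shown here, no step between measured compounds is available to calibrate this change. Given that compound 2 with a carbon-only ring on the carbonyl gives 120 nM, compound 4 is expected to land near 800 nM, within 150 nM to 5000 nM. The expected step of an at least 12-fold lower number from compound 3 to compound 4 (1.09 log units; beyond the scatter) is toward an effect at smaller amounts and beyond the scatter.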

Compound 4, half-maximal effective concentration: 410 nM
Compound 4: the middle estimate sits 2.0-fold (0.29 log units) above what was measured; the measured number falls inside the stated range.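

On a carbonyl carbon whose other neighbour is an amide-type nitrogen in a ring, 3-methylcyclohexyl in place of 4-methoxypiperidin-1-yl gives an at least 24-fold lower number from compound 3 to compound 4 (1.38 log units; beyond the scatter) in this assay. This single change is enough to bring the series off the limit with the 3-chlorophenyl group kept. Compound 3 gives only a limit, so the full size of the step cannot be read: the limit of > 10000 nM in this assay, at which 2 of the 4 values shown sit.

Open, on these data alone, is which part of the change carries the step: the ring nitrogen, the methoxy group or the methyl. Plain cyclohexyl or 4-methoxycyclohexyl on the same carbonyl would separate these.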